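Brominated lactone series: dibromomethyl analogue of compound 2

This account rests on a few compounds, and the source may have more. Where it says the series, first, only, none or still open, it means among the compounds named here.

Measured so far:
- compound 1 `CCC[C@@H](OC(C)=O)C1=C(Br)/C(=C/Br)OC1=O`: 1.6 ug/mL
- compound 2 `CCC[C@@H](OC(C)=O)C1=C(Br)[C@@](C)(OC)OC1=O`: 2.4 ug/mL
- compound 3 `CCC[C@@H](O)C1=C(Br)/C(=C\Br)OC1=O`: 0.3 ug/mL

In a functional assay on ZR-75-1 cells (Homo sapiens) for cytotoxicity (on this read-out higher numbers stand for an effect only at larger amounts of compound and lower numbers for an effect already at smaller amounts), compound 2 gives 2.4 ug/mL, the highest of the three numbers. Compound 1 gives 1.6 ug/mL, which lies within the scatter of compound 2, so no order between the two is read. Compound 3 gives 0.3 ug/mL, and its gap to compound 2 lies beyond the scatter. For the measured compounds named here, no pair of measured compounds differs in one place only, so no single step has been isolated.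

Compound 4 `CCC[C@@H](OC(C)=O)C1=C(Br)[C@](OC)(C(Br)Br)OC1=O` is not yet measured. It differs from compound 2 as follows: dibromomethyl in place of methyl on a saturated ring carbon. Going by the values given here, no measured pair informs on this exchange, and the shared core otherwise stays as in compound 2, so the expectation rests on compound 2 alone.

For compound 4 a step of a 1.6-fold lower number from compound 2 to compound 4 (0.20 log units; within the scatter) is expected, estimated as no more than a modest shift and possibly none beyond the scatter. Compound 4 is therefore estimated at 1.5 ug/mL in this assay, with a range from 0.4 ug/mL to 6 ug/mL that reflects the absence of any measured precedent for the change.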

Compound 4, concentration for half-maximal effect: 3.8 ug/mL
The estimate for compound 4 lay 2.5-fold (0.40 log units) below the measured number, within the range that was stated.
By their numbers in this assay, from the lowest: compound 3; then compounds 1, 2 and 4 (each within the scatter of the next, the first and the last beyond it).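

In this assay, for the compounds shown here, dibromomethyl in place of methyl on a saturated ring carbon gives a 1.6-fold higher number from compound 2 to compound 4 (0.20 log units; within the scatter), the first step that isolates a change in one place. At this carbon, next to the ring oxygen, the read-out therefore does not separate dibromomethyl from methyl, so this pair shows no sensitivity to the exchange, although it tests only these two groups. No measurement is available here that bears on why the exchange leaves the number within the scatter.

From the compounds shown here alone, it remains open whether another group on this carbon, such as an aminomethyl group, a carboxylic acid or a longer chain such as propyl, would produce a step beyond the scatter, and whether a single bromine in the form of bromomethyl would behave like dibromomethyl. Going by these compounds, it also remains open whether the same exchange would give a similar step with a free hydroxyl on the side chain in place of the acetate ester, since compounds 2 and 4 both carry that ester.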